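A few compounds are considered here, and "the series" means these few. Any claim that something is new, unique, unknown or untested is made for them only; others in the source may bear on it.

Working notes on the series, all read in a functional assay on L5178Y cells (Mus musculus) for inhibition, read by MTT assay, with a stated time of 24 h; a higher number here means a weaker inhibitor, a lower number a stronger inhibitor. Compound 1 `COc1cc(O)c2c(c1)O[C@H](c1ccc(OCC3CO3)cc1)CC2=O`, carrying oxiran-2-yl, gives >= 11300 nM, which is a limit of the assay and not a number. Compound 2 `COc1cc(O)c2c(c1)O[C@H](c1ccc(OCC(O)CCl)cc1)CC2=O`, carrying 2-chloro-1-hydroxyethyl in that place, gives >= 11300 nM, again a limit. Within the data shown here, compound 3 `COc1cc(O)c2c(c1)O[C@H](c1ccc(OCC(O)CN3CCCCC3)cc1)CC2=O`, carrying 1-hydroxy-2-(piperidin-1-yl)ethyl, gives 9300 nM, the only true number so far. The other two values stand at the limit of >= 11300 nM in this assay, at which 2 of the 3 values shown sit.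

Compound 4 `COc1cc(O)c2c(c1)O[C@H](c1ccc(OCC(O)Cc3c[nH]c4ccccc34)cc1)CC2=O` has 1H-indol-3-yl in place of piperidin-1-yl on a saturated chain carbon, two bonds along the chain from an oxygen on a saturated carbon. The closest measured change at this place is an at least 1.2-fold lower number from compound 2 to compound 3 (0.08 log units; that floor lies within the scatter). The wider change gives an at least 1.2-fold lower number from compound 1 to compound 3 (0.08 log units; that floor lies within the scatter), and a step that the two limits leave unreadable from compound 1 to compound 2. Neither readable step is shown beyond the scatter, and both are only floors, so the true sizes remain open. No step beyond the scatter is therefore expected in this assay, in either direction. The expected step is a 1.1-fold lower number from compound 3 to compound 4 (0.04 log units; within the scatter). Compound 4 is estimated at 8500 nM, with an expected range of 3500 nM to 16000 nM. A reading that returns only a limit is also a real possibility.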

Compound 4, half-maximal inhibitory concentration: >= 11300 nM
Compound 4 gave a limit, no number (the forecaster's own chance of this, stated with the estimate: 35%); middle value at least 1.3-fold (0.12 log units) away from the limit.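

In this assay, 1H-indol-3-yl in place of piperidin-1-yl on a saturated chain carbon, two bonds along the chain from an oxygen on a saturated carbon, gives an at least 1.2-fold higher number from compound 3 to compound 4 (0.08 log units; that floor lies within the scatter), and this floor does not set compound 4 apart from compound 3. Compound 4 gives >= 11300 nM, a limit of the assay and not a number, so a group with one five-membered aromatic ring and one six-membered aromatic ring at this place adds no second true number to the series. The steps from compound 1 to compound 2 and from compound 2 to compound 4 cannot be read, and the series still holds a single true number, that of compound 3, with the rest at one limit: the limit of >= 11300 nM in this assay, at which 3 of the 4 values shown sit.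

On these data alone, the true size of the step from compound 3 to compound 4 stays open, as only its floor is known. Also open, as far as these compounds go, is how morpholin-4-yl or an open-chain amine such as diethylamino would read at this place, and whether any group here gives a step beyond the scatter from compound 3.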